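The compounds below may be only part of what the source reports. "The series", "measured", "known", "first", "only" and "open" are said of these compounds alone.

In a functional assay (blood) for inhibition, with Homo sapiens as the target (on this read-out higher numbers stand for weaker inhibition and lower numbers for stronger inhibition), three compounds have been measured:

Compound 1, `CC(C)(C)Sc1c(CC(C)(C)C(=O)O)n(Cc2ccc(Cl)cc2)c2ccc(OCc3ccc4cnccc4n3)cc12`, gives 980 nM.
Compound 2, `CC(C)(C)Sc1c(CC(C)(C)C(=O)O)n(Cc2ccc(Cl)cc2)c2ccc(OCc3nc4cc(C(F)(F)F)ccc4s3)cc12`, gives > 3000 nM, which is a limit of the assay rather than a number.
Compound 3, `CC(C)(C)Sc1c(CC(C)(C)C(=O)O)n(Cc2ccc(Cl)cc2)c2ccc(OCc3nc4ccccc4o3)cc12`, gives 2500 nM.

Within the data shown here, compound 3 holds the highest of the two numbers; its nearest neighbour is compound 1, and the single step between measured compounds, a 2.6-fold higher number from compound 1 to compound 3 (0.41 log units; beyond the scatter), is modest. The remaining value, that of compound 2, sits at the limit of > 3000 nM in this assay, at which 1 of the 3 values shown sits.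

Compound 4, `CC(C)c1csc(COc2ccc3c(c2)c(SC(C)(C)C)c(CC(C)(C)C(=O)O)n3Cc2ccc(Cl)cc2)n1`, is not yet measured. It differs from compound 3 in one place: 4-isopropyl-1,3-thiazol-2-yl in place of 1,3-benzoxazol-2-yl on a saturated chain carbon bound to an oxygen on an aromatic ring. Among the measured compounds shown here, the only measured step that bears on this change is the one at the same place, a 2.6-fold higher number from compound 1 to compound 3 (0.41 log units; beyond the scatter), where exchanging the group on the saturated chain carbon bound to an oxygen on an aromatic ring moved the number modestly. Compound 2 shows that a change at the same place can also push the number out to the limit of the assay. For the measured compounds named here, no measured compound carries a group with a single five-membered aromatic ring at this place, so the direction of the step is open; a modest step in either direction is expected, with a real chance of a limit.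

For compound 4, the estimate in this assay is 2200 nM, within 700 nM to 7000 nM. This estimate means a step of a 1.1-fold lower number from compound 3 to compound 4 (0.06 log units; within the scatter), expected to stay close to compound 3.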

Compound 4, half-maximal inhibitory concentration: > 3000 nM
Compound 4: no number, only a limit (the forecaster's own chance of this, stated with the estimate: 30%); middle value at least 1.3-fold (0.13 log units) from the limit.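

In this assay, 4-isopropyl-1,3-thiazol-2-yl on the saturated chain carbon bound to an oxygen on an aromatic ring is clearly poorer than the group of compound 1, with an at least 3.0-fold higher number from compound 1 to compound 4 (0.48 log units; beyond the scatter). Against 1,3-benzoxazol-2-yl the reading is less firm, with an at least 1.2-fold higher number from compound 3 to compound 4 (0.07 log units; that floor lies within the scatter), so this result alone does not establish that compound 4 is weaker than compound 3. A group with a single five-membered aromatic ring therefore brings no gain at this place, and compound 4 joins compound 2 at the limit, where neither has a number: the limit of > 3000 nM in this assay, at which 2 of the 4 values shown sit.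

The compounds shown cannot separate the part played by the isopropyl group from that of the thiazole ring; a plain 1,3-thiazol-2-yl group, or one carrying an amine or a carboxylic acid in place of the isopropyl, would speak to that. Going by these compounds, how far compound 2 and compound 4 lie past the limit, and how they rank against each other, also stays open.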